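The source may hold more compounds than are shown below. What is called first, only, known or untested is meant among the compounds shown, and "the series" means these compounds.

Working notes on the series. In an assay on cells for inhibition of endothelial lipase (Homo sapiens), read by LC-MS, with stated times of 10 min and 30 min (on this read-out higher numbers stand for weaker inhibition and lower numbers for stronger inhibition), compound 1 `Nc1c(C(=O)N[C@H]2CC[C@@H](c3ccccc3)CC2)[nH]c(=O)[nH]c1=O` gives 91 nM, compound 2 `CO[C@]1(c2ccc(F)cc2)CC[C@@H](NC(=O)c2[nH]c(=O)[nH]c(=O)c2N)CC1` gives 1010 nM, and compound 3 `Nc1c(C(=O)N[C@@H]2CC[C@H](c3ccccc3)C2)[nH]c(=O)[nH]c1=O` gives 175 nM. For the measured compounds named here, compound 3 holds the second highest of the three numbers measured so far; its number and that of compound 1 lie within the scatter of each other, so no order between them is claimed, whereas the number of compound 2 stands well beyond the scatter above that of compound 3.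

Compound 4 `Nc1c(C(=O)N[C@H]2CC[C@@H](c3ccccc3)C2)[nH]c(=O)[nH]c1=O` is the next case. Relative to compound 3 the change is the two compounds have the same atoms and bonds and differ only in configuration as drawn: 2 of 2 stereo elements differ (all stereocentres are inverted: mirror images); a stereocentre at a saturated ring carbon is drawn R in compound 3 and S in compound 4; a stereocentre at a saturated ring carbon is drawn S in compound 3 and R in compound 4. Going by the values given here, no measured pair in this set shows what inverting both centres of this ring does, so the size of the step is not anchored. For a mirror image a weaker number is the more common outcome, but a step within the scatter cannot be ruled out. For compound 4 in this assay the estimate is 500 nM, with a range from 120 nM to 3000 nM. That estimate corresponds to an expected step of a 2.9-fold higher number from compound 3 to compound 4 (0.46 log units; beyond the scatter), toward weaker inhibition.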

Compound 4, half-maximal inhibitory concentration: 218 nM
Compound 4: middle estimate off by 2.3-fold (0.36 log units), on the high side; the range from low to high includes it.
By their numbers in this assay, from the lowest: compounds 1, 3 and 4 (each within the scatter of the next, the first and the last beyond it); then compound 2.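

In this assay the result is a 1.2-fold higher number from compound 3 to compound 4 (0.10 log units; within the scatter), so inverting both centres of this saturated ring gives no difference that can be separated from the scatter. For the compounds shown here, this is the first pair that differs in one place, and it shows that, for this pair, the two mirror images are not told apart on this read-out. No other structural change enters the comparison: the fact that compounds 3 and 4 differ only in the configuration as drawn

The compounds shown leave open what inverting only one of the two centres would do, as this pair inverts both together. They also leave open whether the two mirror images would remain as close with an added group on this saturated ring, such as an amine or a carboxylic acid.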